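A few compounds are considered here, and "the series" means these few. Any claim that something is new, unique, unknown or untested is made for them only; others in the source may bear on it.

In a functional assay on HT-29 cells (Homo sapiens) for inhibition, read by MTT assay, with a stated time of 48 h (on this read-out higher numbers stand for weaker inhibition and lower numbers for stronger inhibition), compound 1, `COc1ccc(-n2c(S)nnc2-c2cc(OC)c(OC)c(OC)c2)cc1`, reads > 60000 nM, which is a limit of the assay and not a number. In this assay compound 2, `COc1ccc(-n2c(SCc3ccccc3)nnc2-c2cc(OC)c(OC)c(OC)c2)cc1`, reads > 60000 nM, again a limit. In this assay compound 3, `COc1cc(-c2nnc(SCc3ccccc3)n2-c2ccc(N(C)C)cc2)cc(OC)c1OC`, reads > 60000 nM, also a limit. Within the data shown here, the series so far therefore sits in one place: the limit of > 60000 nM in this assay, at which 3 of the 3 values shown sit.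

Compound 4, `COc1ccc(C(=O)CSc2nnc(-c3cc(OC)c(OC)c(OC)c3)n2-c2ccc(N(C)C)cc2)cc1`, has not yet been measured. It differs from compound 3 as follows: (4-methoxyphenyl)carbonyl in place of phenyl on a saturated chain carbon bound to a sulfur. In words, (4-methoxyphenyl)carbonyl stands in place of phenyl on a saturated chain carbon bound to a sulfur, so benzyl becomes ((4-methoxyphenyl)carbonyl)methyl.

Among the measured compounds shown here, two measured steps bear on this change: a step that the two limits leave unreadable from compound 1 to compound 2, which put benzyl on the sulfur, and a step that the two limits leave unreadable from compound 2 to compound 3, which brought in the dimethylamino group. Neither has a size that can be carried over, so the data fix no expected size. For compound 3 the limit > 60000 nM leaves only one readable direction, towards stronger inhibition, and compound 4 may well stay at that same limit.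

The expected change, held loosely, is an at least 4.0-fold lower number from compound 3 to compound 4 (0.60 log units; beyond the scatter). Compound 4 is estimated at 15000 nM, with an expected range of 500 nM to 60000 nM.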

Compound 4, half-maximal inhibitory concentration: 64000 nM
Estimate against measurement, compound 4: 4.3-fold (0.63 log units) below; measured number above the stated range.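

In this assay compound 3 gives > 60000 nM, which is a limit of the assay and not a number. Compound 4 reads 64000 nM, so no size can be read for the step between compound 3 and compound 4. The compounds shown leave open which change to the shared core, if any, would give clear inhibition in this assay: the limit of > 60000 nM in this assay, at which 3 of the 4 values shown sit.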